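Hydroxy to butoxy on compound 2

The compounds below may be only part of what the source reports. "The series", "measured", "known", "first", "only" and "open" are said of these compounds alone.

In a functional assay on HL-60 cells (Homo sapiens) for cytotoxicity, read by WST assay, with a stated time of 48 h (on this read-out higher numbers stand for an effect only at larger amounts of compound and lower numbers for an effect already at smaller amounts), compound 1 (`Cc1cccc(C[C@H]2C(=O)OC[C@@H]2Cc2ccccc2)c1`) gives 53000 nM and compound 2 (`O=C1OC[C@H](Cc2ccccc2O)[C@H]1Cc1ccc(Cl)c(Cl)c1`) gives 33000 nM, two numbers within the usual scatter of each other. Compound 3 (`CCCCOc1ccccc1C[C@H]1COC(=O)[C@@H]1Cc1ccc(Cl)c(Cl)c1`) differs from compound 2 by turning hydroxy to butoxy: butyl in place of hydrogen on an oxygen on an aromatic ring, with butyl in place of hydrogen on an oxygen on an aromatic ring. Among the compounds with values here, no measured pair shows what a change in one place does in this assay, so the expectation is tentative: a modest move towards a lower number, slightly beyond the scatter. The expected step is a 2.2-fold lower number from compound 2 to compound 3 (0.34 log units; beyond the scatter). For compound 3 the estimated value is 15000 nM, with an expected range from 5000 nM to 50000 nM.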

Compound 3, half-maximal effective concentration: 10000 nM
Estimate against measurement, compound 3: 1.5-fold (0.18 log units) above; the measured number falls inside the stated range.
By their numbers in this assay, from the lowest: compound 3; then compounds 2 and 1 (each within the scatter of the next).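

Within the data shown here, putting butyl in place of hydrogen on the oxygen on the aromatic ring gives the first change in one place that can be read in this assay: it is a 3.3-fold lower number from compound 2 to compound 3 (0.52 log units; beyond the scatter) and so shows that this oxygen can carry butyl with a move to a lower number that lies beyond the scatter. Nothing measured alongside this step accounts for it. The compounds shown leave open whether a shorter chain such as methyl or a longer chain such as octyl on this oxygen would go further. They also leave open what an amine in place of this oxygen would do.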